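The source may report more compounds than this note shows. Statements on the series, on what has been measured and on what is new or still open speak of the compounds shown alone.

Working notes on the series. Two compounds carry numbers in an assay on HEK293 cells for activation of Kir3.1/Kir3.2 (Homo sapiens), read by thallium flux; a higher number here means that more compound is needed for the effect, a lower number that less compound is needed. Compound 1 `O=C(Cn1nnc(-c2ccccc2)n1)NC1CC2CCC1C2` gives 1980 nM in this assay. Compound 2 `Cc1cc(NC(=O)Cn2nnc(-c3ccccc3)n2)n(C2CCOCC2)n1` gives 435 nM in this assay. Compound 2 therefore holds the lowest of the two numbers shown; its only neighbour, compound 1, sits higher by a gap beyond the usual scatter. The two differ across the whole amide side, so their values show only that the amide part of compound 2 needs less compound than that of compound 1.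

Compound 3 `CCC(C)n1nc(C)cc1NC(=O)Cn1nnc(-c2ccccc2)n1` has not yet been measured in this assay. It differs from compound 2 in one place: sec-butyl in place of oxan-4-yl on an aromatic nitrogen. For the measured compounds named here, no measured pair isolates this change, so nothing on hand tells how the ring compares with the open chain at this position. The methyl group and the five-membered aromatic ring with 2 nitrogen are kept. The expected step in this assay is a 1.5-fold higher number from compound 2 to compound 3 (0.17 log units; within the scatter), small, and could be in either direction or none beyond the scatter. Compound 3 is estimated at 650 nM in this assay, with a range of 200 nM to 2100 nM.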

Compound 3, half-maximal effective concentration: > 5000 nM
Compound 3: a limit, no number (the forecaster's own chance of this, stated with the estimate: 5%); at least 7.6-fold (0.88 log units) between middle value and limit.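

In this assay compound 3 gives > 5000 nM, which is a limit of the assay and not a number. For the compounds shown here, this is the first pair that differs in one place, and sec-butyl in place of oxan-4-yl on an aromatic nitrogen brings an at least 11-fold higher number from compound 2 to compound 3 (1.06 log units; beyond the scatter), so the group at this position matters strongly in a way that the whole-amide difference of compound 1 and compound 2 could not show. On these data alone, the oxan-4-yl ring and the open chain are therefore not interchangeable here, and the full size of the step stays unknown, since the reading for compound 3 stops at the limit: the limit of > 5000 nM in this assay, at which 1 of the 3 values shown sits.

The change removes the ring, the ring oxygen and some heavy atoms all at once, so this pair cannot say which of these matters. Cyclohexyl would keep the ring without the oxygen and 2-methoxyethyl would keep an oxygen without the ring, and only such groups at this position could separate the two.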